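Trifluoromethyl to methyl swap and cytotoxicity in keratinocytes

The source may report more compounds than this note shows. Statements on the series, on what has been measured and on what is new or still open speak of the compounds shown alone.

In an ADME assay on HaCaT cells (Homo sapiens) for cytotoxicity, read by MTT assay, with a stated time of 48 h (on this read-out lower numbers stand for stronger inhibition and higher numbers for weaker inhibition), compound 2 `FC(F)(F)c1ccc2[nH]c(-c3cn(-c4ccccc4)nc3-c3ccccc3)nc2c1` gives 37200 nM. Compound 1 `Cc1ccc2[nH]c(-c3cn(-c4ccccc4)nc3-c3ccccc3)nc2c1` reaches only the limit of this assay, > 50000 nM. Compound 3 `COc1ccc(-c2nn(-c3ccccc3)cc2-c2nc3cc(C(F)(F)F)ccc3[nH]2)cc1` likewise reaches only the limit, > 50000 nM. Accordingly an at least 1.3-fold higher number from compound 2 to compound 1 (0.12 log units; that floor lies within the scatter), and an at least 1.3-fold higher number from compound 2 to compound 3 (0.12 log units; that floor lies within the scatter); both floors rest on (the limit of > 50000 nM in this assay, at which 2 of the 3 values shown sit).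

Compound 4 `COc1ccc(-c2nn(-c3ccccc3)cc2-c2nc3cc(C)ccc3[nH]2)cc1` has not yet been measured in this assay. It differs from compound 3 by methyl in place of trifluoromethyl on an aromatic carbon. The same change, from compound 2 to compound 1, is methyl in place of trifluoromethyl on an aromatic carbon and gave an at least 1.3-fold higher number from compound 2 to compound 1 (0.12 log units; that floor lies within the scatter). The cores of compound 3 and compound 2 differ by methoxy in place of hydrogen on an aromatic carbon. Because compound 3 already sits at the limit > 50000 nM, the step to compound 4 is expected to be a step that the limit leaves unreadable from compound 3 to compound 4. Compound 4 is therefore expected to give 80000 nM in this assay, most likely again reported only as a limit.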

Compound 4, half-maximal inhibitory concentration: > 50000 nM
Compound 4 gave a limit, no number; the forecaster's own chance of this, stated with the estimate: 85%; the middle value is on the limit's open side.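

Compound 4 stands at a limit in this assay, as do compound 1 and compound 3, so no new step to compound 4 can be read: the limit of > 50000 nM in this assay, at which 3 of the 4 values shown sit.

As far as these compounds go, whether compound 1, compound 3 and compound 4 differ from one another remains open.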